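The source may hold more compounds than are shown below. What is called first, only, known or untested is meant among the compounds shown, and "the series" means these compounds.

Of the compounds shown here, three sharing one core have been tested in a functional assay (aorta) for antagonist activity, with Oryctolagus cuniculus as the target; a lower number here means a stronger inhibitor, a higher number a weaker inhibitor. Compound 1 `CCCCc1ccc(CNC(=O)OC(C)(C)C)c(=O)n1Cc1ccc(-c2ccccc2-c2nn[nH]n2)cc1` gives 10 nM in this assay, compound 2 `CCCCc1ccc(CN)c(=O)n1Cc1ccc(-c2ccccc2-c2nn[nH]n2)cc1` gives 20 nM, and compound 3 `CCCCc1ccc(CN(C)S(=O)(=O)c2ccc(C)cc2)c(=O)n1Cc1ccc(-c2ccccc2-c2nn[nH]n2)cc1` gives 8 nM. Compound 2 therefore holds the highest of the three numbers; the step of a 2.0-fold higher number from compound 1 to compound 2 (0.30 log units; within the scatter) lies within the scatter, whereas the step of a 2.5-fold lower number from compound 2 to compound 3 (0.40 log units; beyond the scatter) lies beyond it. Compound 4 `CCCCc1ccc(CN(C(C)C)S(C)(=O)=O)c(=O)n1Cc1ccc(-c2ccccc2-c2nn[nH]n2)cc1` has not yet been measured. It differs from compound 2 in one place: isopropyl(methylsulfonyl)amino in place of amino on a saturated chain carbon bound to an aromatic carbon. The closest guide is the step of a 2.5-fold lower number from compound 2 to compound 3 (0.40 log units; beyond the scatter), in which amino was likewise replaced by a larger group, methyl((4-methylphenyl)sulfonyl)amino, on a saturated chain carbon bound to an aromatic carbon. The step of a 1.3-fold lower number from compound 1 to compound 3 (0.10 log units; within the scatter) adds that another large group at this place gave a number no higher than that of compound 1. A modest lowering of the number is therefore expected for compound 4, about a 2.2-fold lower number from compound 2 to compound 4 (0.35 log units; beyond the scatter). Compound 4 is estimated to give 9 nM in this assay, with a range from 4 nM to 20 nM.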

Compound 4, half-maximal inhibitory concentration: 0.9 nM
For compound 4 the middle estimate is 10-fold (1.00 log units) above the measured one; measured number outside the range, below it.
By their numbers in this assay, from the lowest: compound 4; then compounds 3, 1 and 2 (each within the scatter of the next, the first and the last beyond it).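

Compound 4 shows that this position can give a far lower number than the earlier groups suggested: replacing amino with isopropyl(methylsulfonyl)amino gives a 22-fold lower number from compound 2 to compound 4 (1.35 log units; beyond the scatter) in this series. Replacing (tert-butoxycarbonyl)amino gives a similar gain (an 11-fold lower number from compound 1 to compound 4 (1.05 log units; beyond the scatter)), so the gain does not depend on the free amine of compound 2 as the starting point. Compound 3 also carries a sulfonyl group on this nitrogen, yet the step to compound 4 is still an 8.9-fold lower number from compound 3 to compound 4 (0.95 log units; beyond the scatter) at this place, so a sulfonyl group alone does not give the low number.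

That step changes the groups on both the nitrogen and the sulfur at once, and methyl(methylsulfonyl)amino would help show which change matters. No evidence here explains why this group gives so low a number.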